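This account rests on a few compounds, and the source may have more. Where it says the series, first, only, none or still open, it means among the compounds named here.

Compound 1 `CCCN1CCN(c2nc3ccccc3n2CCOCC)CC1` gives 16 nM in a functional assay on ileum for inhibition of histamine H1 receptor (Cavia porcellus); a higher number here means a weaker inhibitor, a lower number a stronger inhibitor.
Compound 2 `C#CCOCCn1c(N2CCN(C)CC2)nc2ccccc21` gives 12 nM in this assay.
Compound 3 `CCCCCN1CCCN(c2nc3ccccc3n2CCOCC)CC1` gives 7.4 nM in this assay.

Among these three numbers compound 2 has the second highest, yet compound 1 and compound 3 both lie within the scatter of it, so no order can be read from them. Compound 4 `CCCC(C)n1c(N2CCN(C)CC2)nc2ccccc21` differs from compound 2 in a single place: 1-methylbutyl in place of 2-(propargyloxy)ethyl on an aromatic nitrogen. Going by the values given here, no pair of measured compounds shows this kind of change, so there is no measured step to lean on. Because compound 1 gives 16 nM while compound 2 gives 12 nM and compound 3 gives 7.4 nM in this assay despite their differing groups on that ring nitrogen, only a small step in this assay is expected, if any beyond the scatter. The estimate that follows means a step of a 1.7-fold higher number from compound 2 to compound 4 (0.22 log units; within the scatter). Compound 4 is expected to give 20 nM, between 6 nM and 60 nM.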

Compound 4, half-maximal inhibitory concentration: 1400 nM
Estimate against measurement, compound 4: 70-fold (1.85 log units) below; the whole stated range lies below it.
By their numbers in this assay, from the lowest: compounds 3, 2 and 1 (each within the scatter of the next, the first and the last beyond it); then compound 4.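

In this assay, 1-methylbutyl in place of 2-(propargyloxy)ethyl on the aromatic nitrogen gives a 120-fold higher number from compound 2 to compound 4 (2.07 log units; beyond the scatter) as a large step, so this position can matter greatly. The group that leaves carries a triple bond and a hydrogen-bond acceptor, while the group that enters has neither, so this single swap cannot separate those features. Nothing available here explains the size of the step.

From the compounds shown here alone, it remains open whether a straight pentyl chain or a 2-methoxyethyl group on this nitrogen would keep the number close to that of compound 2.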